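A Benzoyl Group Added to a Second Anilide Core

The source may hold more compounds than are shown below. What is called first, only, known or untested is meant among the compounds shown, and "the series" means these compounds.

Measured compounds and their values:
Compound 1, `O=C(Nc1ccccc1O)C1CCc2ccccc2N1C(=O)c1ccccc1`: in a functional assay on PC-3 cells (Homo sapiens) for cytotoxicity, read by sulforhodamine B assay, with a stated time of 72 h (on this read-out lower numbers stand for stronger inhibition of growth and higher numbers for weaker inhibition of growth), compound 1 gives 5690 nM.
Compound 2, `O=C(Nc1ccccc1O)C1CCc2ccccc2N1`: in this assay compound 2 gives 4310 nM.
Compound 3, `O=C(Nc1cc(C(F)(F)F)cc(C(F)(F)F)c1)C1CCc2ccccc2N1`: in this assay compound 3 gives 8120 nM.

Compound 2 and compound 1 share a core and differ in one place: benzoyl in place of hydrogen on a nitrogen on an aromatic ring in a ring. The step in this assay that accompanies this change is a 1.3-fold higher number from compound 2 to compound 1 (0.12 log units; within the scatter), so the two values sit within the usual spread of repeated measurements and neither can be called stronger than the other.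

Compound 3 carries a different anilide part; the difference between its core and that of compound 2 is not broken down here. The values of compound 2 and compound 3 in this assay lie within the scatter of each other.

Compound 4, `O=C(Nc1cc(C(F)(F)F)cc(C(F)(F)F)c1)C1CCc2ccccc2N1C(=O)c1ccccc1`, is not yet measured. It relates to compound 3 exactly as compound 1 relates to compound 2: benzoyl in place of hydrogen on a nitrogen on an aromatic ring in a ring. The change is the same in both pairs, and its place is described in the same words.

On the basis of the step seen from compound 2 to compound 1, the same change applied to compound 3 is expected to give a step of about a 1.3-fold higher number from compound 3 to compound 4 (0.11 log units; within the scatter) in this assay, again within the scatter. Compound 4 is therefore estimated at 10500 nM in this assay, with a likely range from 4000 nM to 26000 nM, because this expectation rests on one prior step, a 1.3-fold higher number from compound 2 to compound 1 (0.12 log units; within the scatter).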

Compound 4, concentration for 50% growth inhibition: 3500 nM
Beside the measured number, compound 4's estimate is 3.0-fold (0.48 log units) above it; measured number below the stated range.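

In this assay, benzoyl in place of hydrogen on a nitrogen on an aromatic ring in a ring gives a 2.3-fold lower number from compound 3 to compound 4 (0.37 log units; beyond the scatter), a modest step that lies beyond the scatter. Set beside the earlier step, the same change did not behave alike on the two cores: the same change on two cores in this assay, a 1.3-fold higher number (0.12 log units; within the scatter) from compound 2 to compound 1 and a 2.3-fold lower number (0.37 log units; beyond the scatter) from compound 3 to compound 4, 3.1-fold (0.49 log units) apart, beyond the scatter of two such steps. Going by these compounds alone, this shows that, in this series, the step seen on one core could not be carried over to the other, for the change left the values of one pair within the scatter and lowered the number on the core bearing the two trifluoromethyl groups, but with only two pairs it does not show why the cores part ways or which feature of the anilide part goes with the difference.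

The compounds shown leave open whether a smaller acyl group such as acetyl, or a simple methyl, on the same nitrogen would also lower the number on the core of compound 3. They also leave open how the change would behave on a further core, for example one whose anilide ring carries a single trifluoromethyl group or a methoxy group.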